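Swapping a Hydroxypropyl Chain for a Dihydroxyethyl Chain

The source may hold more compounds than are shown below. What is called first, only, known or untested is meant among the compounds shown, and "the series" means these compounds.

Measured so far:
Compound 1 `C[C@@H](O)CCn1nc2c(Br)c(Br)c(Br)c(Br)c2n1` gives 69% in a functional assay on CCRF-CEM cells (Homo sapiens) for antiproliferative activity, read by MTT assay, with a stated time of 24 h, tested at 50 uM; on this read-out lower numbers stand for a stronger effect and higher numbers for a weaker effect at the one concentration tested.
Compound 2 `OC(CCn1nc2c(Br)c(Br)c(Br)c(Br)c2n1)c1ccc(Br)cc1` gives 58% in this assay.
Compound 3 `OC(CCn1nc2c(Br)c(Br)c(Br)c(Br)c2n1)c1ccc(Cl)cc1` gives 56% in this assay.

All three share the same brominated core and differ only in the chain that hangs from the aromatic nitrogen. Compound 1 stands highest of the three numbers, which in this assay means the weakest effect; compound 2 and compound 3 both lie lower, beyond the usual scatter. Among the compounds with values here, the only measured step that changes one place is a number 2 percentage points lower from compound 2 to compound 3 (within the scatter), and it stays within the scatter.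

Compound 4 `OCC(O)Cn1nc2c(Br)c(Br)c(Br)c(Br)c2n1` differs from compound 1 by 1,2-dihydroxyethyl in place of 2-hydroxypropyl on a saturated chain carbon bound to an aromatic nitrogen. Within the data shown here, no measured step bears on this change: the one step available swaps a halogen on an aromatic ring, not a hydroxyl on the chain. The expectation is therefore a step of a number 1 percentage points lower from compound 1 to compound 4 (within the scatter), which is not beyond the scatter. Compound 4 is expected to give about 68%, in a range from 54% to 82%.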

Compound 4, a percentage reported as activity, at one concentration (the size of the read-out at that concentration, not a potency): 47%
Beside the measured number, compound 4's estimate is 21 percentage points above it, and the stated range ends above it.
By their numbers in this assay, from the lowest: compounds 4, 3 and 2 (each within the scatter of the next, the first and the last beyond it); then compound 1.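

In this assay, 1,2-dihydroxyethyl in place of 2-hydroxypropyl gives a number 22 percentage points lower from compound 1 to compound 4 (beyond the scatter) on the shared core. Within the data shown here, the only earlier one-place step, a number 2 percentage points lower from compound 2 to compound 3 (within the scatter), swapped a halogen on an aromatic ring, so this is the first sign that a small edit on a saturated chain carbon bound to an aromatic nitrogen can move the number beyond the scatter. The two chains have the same heavy-atom count, but the change adds an oxygen in place of a carbon and removes the defined stereocentre, and this single pair cannot separate those two differences. Nothing measured here explains the step.

Still open, on these data alone, is whether a second hydroxyl is specifically needed. A methoxy group, an amine or a carboxylic acid at the end of the chain would test that, and a longer chain carrying both hydroxyls would show how far the effect extends.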